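Trading trifluoromethyl for fluoro on a growth inhibitor

This account rests on a few compounds, and the source may have more. Where it says the series, first, only, none or still open, it means among the compounds named here.

Within the data shown here, in a functional assay on UACC-62 cells (Homo sapiens) (on this read-out higher numbers stand for weaker inhibition of growth and lower numbers for stronger inhibition of growth), compound 1 `O=S(=O)(/C=C/c1ccc(Cl)cc1Cl)Cc1ccc(Nc2ncnc3ccc(Br)cc23)cc1` gives 2000 nM and compound 2 `O=S(=O)(/C=C/c1ccc(C(F)(F)F)cc1F)Cc1ccc(Nc2ncnc3ccc(Br)cc23)cc1` gives 22000 nM as the higher of the two numbers so far. Among the measured compounds shown here, the only measured step, which changes groups on the same aromatic ring, is an 11-fold higher number from compound 1 to compound 2 (1.04 log units; beyond the scatter) and it counts as large. Compound 3 `O=S(=O)(/C=C/c1ccc(F)cc1F)Cc1ccc(Nc2ncnc3ccc(Br)cc23)cc1` keeps the rest of compound 2 but has fluoro in place of trifluoromethyl on an aromatic carbon, para to a large group, a change counted as fluoro in place of trifluoromethyl on an aromatic carbon in full. Compound 1 also lacks trifluoromethyl and gives 2000 nM as its number, so in this assay a move toward a lower number is expected, probably smaller than that large step, though a single step is thin evidence. The estimated move is a 3.1-fold lower number from compound 2 to compound 3 (0.50 log units; beyond the scatter) and it remains uncertain. Compound 3 is expected at 7000 nM with an estimated range from 2000 nM to 22000 nM for repeat measurements.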

Compound 3, concentration for 50% growth inhibition: 3000 nM
Estimate against measurement, compound 3: 2.3-fold (0.37 log units) above; low and high end bracket the measured number.
By their numbers in this assay, from the lowest: compounds 1 and 3 (each within the scatter of the next); then compound 2.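

Putting fluoro in place of trifluoromethyl on this aromatic carbon, para to a large group, gives in this assay a 7.3-fold lower number from compound 2 to compound 3 (0.87 log units; beyond the scatter) and so ties the weak growth inhibition of compound 2 to the trifluoromethyl group at this position. Changing 2,4-dichlorophenyl to 2,4-difluorophenyl gives a 1.5-fold higher number from compound 1 to compound 3 (0.18 log units; within the scatter) and so does not separate these two halogen patterns in this read-out. Nothing measured here explains why trifluoromethyl stands apart from fluoro at this position.

The compounds shown leave open whether a methoxy group or an amine at this position would fall with compound 3 or with compound 2. They also leave open whether the trifluoromethyl-to-fluoro change would have a similar size if the remaining fluoro on the ring were replaced by chloro.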